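Chain extension from compound 2 to compound 3

The compounds below may be only part of what the source reports. "The series", "measured", "known", "first", "only" and "open" are said of these compounds alone.

Among the compounds with values here, in an in vivo functional assay on the whole organism (MDA-MB-435 cells, Homo sapiens) for antiproliferative activity (a lower number here means a stronger inhibitor, a higher number a weaker inhibitor), compound 1 `CO[C@@H](C(=O)NC1CC[C@@H](OC(=O)c2ccccc2)CNC1=O)[C@H](O)[C@@H](O)[C@H](O)/C=C/C(C)(C)C` gives 370 nM and compound 2 `CO[C@@H](C(=O)NC1CC[C@@H](OC(=O)Cc2cccnc2)CNC1=O)[C@H](O)[C@@H](O)[C@H](O)/C=C/C(C)(C)C` gives 5850 nM, the higher of the two numbers so far. Compound 3 `CO[C@@H](C(=O)NC1CC[C@@H](OC(=O)CCc2cccnc2)CNC1=O)[C@H](O)[C@@H](O)[C@H](O)/C=C/C(C)(C)C` carries (pyridin-3-yl)methyl in place of pyridin-3-yl on a saturated chain carbon bound to a carbonyl carbon. Within the data shown here, the only measured step, a 16-fold higher number from compound 1 to compound 2 (1.20 log units; beyond the scatter), is large but involves a different change, phenyl to (pyridin-3-yl)methyl, and so bears only loosely on this one. No step beyond the scatter is therefore expected in this assay, and the estimated 1.2-fold lower number from compound 2 to compound 3 (0.07 log units; within the scatter) is small. Compound 3 is expected at 5000 nM, with an estimated range of 1500 nM to 16000 nM.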

Compound 3, half-maximal inhibitory concentration: 460 nM
Beside the measured number, compound 3's estimate is 11-fold (1.04 log units) above it; measured number below the stated range.
By their numbers in this assay, from the lowest: compounds 1 and 3 (each within the scatter of the next); then compound 2.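

In this assay, the extra chain carbon alone, with the pyridin-3-yl ring kept, gives a 13-fold lower number from compound 2 to compound 3 (1.10 log units; beyond the scatter) and so shows that this position is sensitive to chain length. Set against phenyl, the record reads a 1.2-fold higher number from compound 1 to compound 3 (0.09 log units; within the scatter) and so phenyl and 2-(pyridin-3-yl)ethyl cannot be told apart here, unlike phenyl and (pyridin-3-yl)methyl. No evidence at hand accounts for the effect of chain length. Open, as far as these compounds go, is whether a longer chain such as 3-(pyridin-3-yl)propyl holds this level, and how 2-phenylethyl compares with 2-(pyridin-3-yl)ethyl.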